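A few compounds are considered here, and "the series" means these few. Any claim that something is new, unique, unknown or untested is made for them only; others in the source may bear on it.

Compound 1 is `Cc1ccc(S(=O)(=O)Nc2ccc3c(c2)C(=O)N(C)C3=O)cc1`. In an assay on isolated protein for inhibition of lysosomal alpha-glucosidase (Rattus norvegicus), read by colorimetric assay (on this read-out lower numbers stand for stronger inhibition and higher numbers for weaker inhibition), compound 1 reaches only the limit > 200000 nM, a bound of the assay and not a number.
Compound 2 is `Cc1ccc(S(=O)(=O)Nc2ccc3c(c2)C(=O)N(CCNc2ccccc2)C3=O)cc1`. In this assay compound 2 gives 99600 nM.
Compound 3 is `Nc1ccc2c(c1)C(=O)N(CCNc1ccccc1)C2=O`. In this assay compound 3 gives 144000 nM.

Compound 3 holds the highest of the two numbers obtained, but its nearest neighbour is compound 2, and the step of a 1.4-fold higher number from compound 2 to compound 3 (0.16 log units; within the scatter) lies within the usual scatter, so the two compounds cannot be told apart on this evidence. Compound 1 contributes no number, only (the limit of > 200000 nM in this assay, at which 1 of the 3 values shown sits).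

Compound 4 is `O=C1c2ccc([N+](=O)[O-])cc2C(=O)N1CCNc1ccccc1`. Relative to compound 3 the change is nitro in place of amino on an aromatic carbon. Of the measured steps, the one that touches the same nitrogen on the aromatic ring is a 1.4-fold higher number from compound 2 to compound 3 (0.16 log units; within the scatter), a change within the scatter. The other step, an at least 2.0-fold lower number from compound 1 to compound 2 (0.30 log units; that floor lies within the scatter), concerns a different part of the molecule and rests on a limit, so it says little here. The expectation for compound 4 is therefore a step of no change at the digits printed from compound 3 to compound 4 (within the scatter), no clear movement in either direction beyond the scatter. The estimated value for compound 4 in this assay is 144000 nM, with a range from 60000 nM to 350000 nM.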

Compound 4, half-maximal inhibitory concentration: 111000 nM
Compound 4: middle estimate off by 1.3-fold (0.11 log units), on the high side, within the range that was stated.
By their numbers in this assay, from the lowest: compounds 2, 4 and 3 (each within the scatter of the next). At a limit, above all of these: compound 1.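

In this assay the replacement of amino by nitro on this aromatic carbon gives a 1.3-fold lower number from compound 3 to compound 4 (0.11 log units; within the scatter) and so does not separate the two compounds. The earlier compounds shown here had changed only what sits on the nitrogen at this place, while here the nitrogen itself changes its partners: a group with a hydrogen-bond donor gives way to one with none and gains a hydrogen-bond acceptor, yet the number stays inside the scatter. Compounds 2, 3 and 4 now show three different groups at this carbon with values that each lie within the scatter of the next, and nothing shown here gives a reason for this flat result.

The three groups seen so far therefore mark out only a narrow sample of what this aromatic carbon can carry, and no group yet moves the number clearly at this place. On these data alone, whether a carboxylic acid, a methoxy group or a chlorine atom on this carbon, or a longer chain on the ring nitrogen of the core, would give a step beyond the scatter stays open.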